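Compound 3 to Compound 4: a Tosylate Enters

The compounds below may be only part of what the source reports. "The series", "measured", "known", "first", "only" and "open" are said of these compounds alone.

Of the compounds shown here, three built on one shared core have been measured in a functional assay on WiDr cells (Homo sapiens) for antiproliferative activity, read by sulforhodamine B assay, with a stated time of 48 h; a higher number here means a weaker inhibitor of growth, a lower number a stronger inhibitor of growth. Compound 1 `Nc1nnc(SC[C@H]2O[C@@H](OCc3noc(-c4ccc([N+](=O)[O-])cc4)n3)[C@@H]3OC4(CCCC4)O[C@@H]32)s1` gives 26000 nM. Compound 2 `CC(=O)OC[C@H]1O[C@@H](OCc2noc(-c3ccc([N+](=O)[O-])cc3)n2)[C@@H]2OC3(CCCC3)O[C@@H]21` gives 36000 nM. Compound 3 `O=[N+]([O-])c1ccc(-c2nc(CO[C@@H]3O[C@H](CSc4ncn[nH]4)[C@H]4OC5(CCCC5)O[C@@H]34)no2)cc1` gives 20000 nM, the lowest of the three numbers, though its gaps to the other two are within the scatter: a 1.3-fold lower number from compound 1 to compound 3 (0.11 log units; within the scatter) and a 1.8-fold lower number from compound 2 to compound 3 (0.26 log units; within the scatter). Compound 4 `Cc1ccc(S(=O)(=O)OC[C@H]2O[C@@H](OCc3noc(-c4ccc([N+](=O)[O-])cc4)n3)[C@@H]3OC4(CCCC4)O[C@@H]32)cc1` differs from compound 3 in one place: ((4-methylphenyl)sulfonyl)oxy in place of (1H-1,2,4-triazol-5-yl)sulfanyl on a saturated chain carbon bound to a saturated ring carbon. The measured steps that bear on this change are the exchanges already made at the same saturated chain carbon, namely a 1.4-fold higher number from compound 1 to compound 2 (0.14 log units; within the scatter) and a 1.8-fold lower number from compound 2 to compound 3 (0.26 log units; within the scatter), with a 1.3-fold lower number from compound 1 to compound 3 (0.11 log units; within the scatter) as the third link. None of them moved this assay beyond the scatter. Among the compounds with values here, no measured step covers a group as large as the one now entering, so the expectation rests on those three small steps alone. Compound 4 is therefore expected to give about 25000 nM in this assay, within a range from 10000 nM to 60000 nM. The step this estimate implies is a 1.3-fold higher number from compound 3 to compound 4 (0.10 log units; within the scatter), expected to stay within the scatter.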

Compound 4, concentration for 50% growth inhibition: > 100000 nM
Compound 4: no number, only a limit (the forecaster's own chance of this, stated with the estimate: 10%); middle value at least 4.0-fold (0.60 log units) from the limit.
By their numbers in this assay, from the lowest: compounds 3, 1 and 2 (each within the scatter of the next). At a limit, above all of these: compound 4.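

In this assay compound 4 gives > 100000 nM, which is a limit of the assay and not a number: the limit of > 100000 nM in this assay, at which 1 of the 4 values shown sits.

This exchange is the only one shown at this saturated chain carbon that goes beyond the scatter, with an at least 5.0-fold higher number from compound 3 to compound 4 (0.69 log units; beyond the scatter), an at least 3.8-fold higher number from compound 1 to compound 4 (0.58 log units; beyond the scatter) and an at least 2.7-fold higher number from compound 2 to compound 4 (0.44 log units; beyond the scatter). The position is therefore not indifferent to what it carries: acetoxy, (5-amino-1,3,4-thiadiazol-2-yl)sulfanyl and (1H-1,2,4-triazol-5-yl)sulfanyl stay within the scatter of one another, while ((4-methylphenyl)sulfonyl)oxy does not.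

The compounds shown do not separate the part played by the sulfonyl from that of the six-membered aromatic ring of carbon only, and how far compound 4 lies past its limit stays unknown. As far as these compounds go, whether a free hydroxyl, an amine or a benzoyl ester on this carbon would stay with the first three compounds or follow compound 4 also remains open.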